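Turning the Double Bond of Compound 2 from Z to E

This account rests on a few compounds, and the source may have more. Where it says the series, first, only, none or still open, it means among the compounds named here.

Compound 1 `CCCCCCCC#CC#CC1=CC(=O)NCCC1` gives > 50 ug/mL in a functional assay on SK-OV-3 cells (Homo sapiens) for cytotoxicity (a higher number here means that more compound is needed for the effect, a lower number that less compound is needed), which is a limit of the assay and not a number.
Compound 2 `CCCCCCCC#CC#C/C=C\C(C)=O` gives 25.9 ug/mL.
Compound 3 `CCCCCCCC#CC#CC1CC(=O)C=C(C)C1` gives 29.2 ug/mL.

Of the two numbers shown, compound 2 holds the lowest, but compound 3 sits within the scatter of it, so the two cannot be told apart. For compound 1 only a limit is known (the limit of > 50 ug/mL in this assay, at which 1 of the 3 values shown sits). Going by the values given here, the next compound is compound 4 `CCCCCCCC#CC#C/C=C/C(C)=O`. the two compounds have the same atoms and bonds and differ only in configuration as drawn: 1 of 1 stereo elements differ; a double bond is drawn Z in compound 2 and E in compound 4 No measured pair shows what such a change does here, so the plain expectation is a step of no size beyond the scatter, in neither direction. Compound 4 is therefore expected at about 25 ug/mL, within 10 ug/mL to 60 ug/mL. The step this estimate means is a 1.0-fold lower number from compound 2 to compound 4 (0.02 log units; within the scatter).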

Compound 4, concentration for half-maximal effect: 3.2 ug/mL
Beside the measured number, compound 4's estimate is 7.8-fold (0.89 log units) above it; the measured number lies below the stated range.
By their numbers in this assay, from the lowest: compound 4; then compounds 2 and 3 (each within the scatter of the next). At a limit, above all of these: compound 1.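

Going by these compounds alone, until now no pair of compounds showed what the geometry of this double bond is worth in this assay, and here turning it from Z to E gives an 8.1-fold lower number from compound 2 to compound 4 (0.91 log units; beyond the scatter). The change of geometry alone accounts for this step, because nothing else in the structures changes: the fact that compounds 2 and 4 differ only in the configuration as drawn.

Still open, as far as these compounds go, is whether an E double bond gives a step of this size when the ketone gives way to a carboxylic acid or an amine, or when the chain is longer. From the compounds shown here alone, whether the step holds on other cell lines also remains open.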